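The compounds below may be only part of what the source reports. "The series", "measured", "known", "first", "only" and "open" are said of these compounds alone.

In a functional assay on MCF7 cells (Homo sapiens) for antiproliferative activity, read by sulforhodamine B assay, with a stated time of 48 h (on this read-out lower numbers stand for stronger inhibition and higher numbers for weaker inhibition), compound 1 (`COc1ccc(C[C@@H](O)/C=C/C=C/C(=O)N2CCCCC2)cc1OC`) gives 39500 nM, compound 2 (`COc1ccc(C[C@@H](O)/C=C/C=C/C(=O)N2CCN(C)CC2)cc1OC`) gives 17100 nM and compound 3 (`COc1ccc(C[C@@H](O)/C=C/C=C/C(=O)N2CCN(c3ccccc3)CC2)cc1OC`) gives 12000 nM. Compound 2 thus lies under compound 1, while its other neighbour is close: a 1.4-fold lower number from compound 2 to compound 3 (0.15 log units; within the scatter). Compound 4 (`COc1ccc(C[C@@H](O)/C=C/C=C/C(=O)N2CCCC2)cc1OC`) carries pyrrolidin-1-yl in place of 4-methylpiperazin-1-yl on a carbonyl carbon. The step that bears most directly on this is a 2.3-fold lower number from compound 1 to compound 2 (0.36 log units; beyond the scatter), where 4-methylpiperazin-1-yl replaced piperidin-1-yl. Compound 4 likewise has a saturated ring without the second nitrogen, so a modest move back towards higher numbers is expected in this assay. The expected change is a 1.8-fold higher number from compound 2 to compound 4 (0.24 log units; within the scatter). Compound 4 is estimated at 30000 nM, with an expected range of 12000 nM to 70000 nM.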

Compound 4, half-maximal inhibitory concentration: 26200 nM
Compound 4: middle estimate off by 1.1-fold (0.06 log units), on the high side; the range from low to high includes it.
By their numbers in this assay, from the lowest: compounds 3, 2, 4 and 1 (each within the scatter of the next, the first and the last beyond it).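

In this assay, pyrrolidin-1-yl on the carbonyl carbon gives a 1.5-fold higher number from compound 2 to compound 4 (0.19 log units; within the scatter) and a 1.5-fold lower number from compound 1 to compound 4 (0.18 log units; within the scatter), so compound 4 cannot be told apart from either neighbour. The five-membered ring thus sits within the scatter of both six-membered rings, even though those two are separated by a 2.3-fold lower number from compound 1 to compound 2 (0.36 log units; beyond the scatter). Nothing available here explains this result.

As far as these compounds go, it remains open how a morpholine ring or an open-chain diethylamine on the same carbonyl carbon would read in this assay, and whether either would leave the range these compounds span.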